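Nitro in Place of Chloro on Two Hydrazone Cores

The source may report more compounds than this note shows. Statements on the series, on what has been measured and on what is new or still open speak of the compounds shown alone.

Four related compounds are compared in an ADME assay on HEL cells (Homo sapiens) for cytotoxicity; on this read-out higher numbers stand for lower toxicity in this test and lower numbers for higher toxicity in this test. Compound 1 `C/C(=N\NC(=O)COc1cccc2ccccc12)c1ccc([N+](=O)[O-])cc1` and compound 2 `C/C(=N\NC(=O)COc1cccc2ccccc12)c1ccc(Cl)cc1` share one core and differ only in the change (nitro in place of chloro on an aromatic carbon). Compound 3 `O=C(COc1cccc2ccccc12)N/N=C/c1ccccc1Cl` is built on a different core; the difference between the two cores is not broken down here. Compound 4 `O=C(COc1cccc2ccccc12)N/N=C/c1ccccc1[N+](=O)[O-]` has not yet been measured and relates to compound 3 through the change (nitro in place of chloro on an aromatic carbon).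

In this assay compound 2 gives 7.1 ug/mL. Compound 1 gives > 100 ug/mL, which is a limit of the assay rather than a number. The step of an at least 14-fold higher number from compound 2 to compound 1 (1.14 log units; beyond the scatter) is therefore open-ended, with one of the three values sitting at the limit of > 100 ug/mL in this assay, at which 1 of the 3 values shown sits. Compound 3 gives 62.7 ug/mL, the higher of the two plain numbers.

The change from compound 3 to compound 4 is the same kind of change as that from compound 2 to compound 1, not the same: in compound 2 the chloro sits para to a large group, while in compound 3 it sits ortho to a large group. The step from compound 2 to compound 1 was large, so a rise of similar direction is expected here, a 2.4-fold higher number from compound 3 to compound 4 (0.38 log units; beyond the scatter), resting on the measured step of an at least 14-fold higher number from compound 2 to compound 1 (1.14 log units; beyond the scatter). Compound 4 is expected to give about 150 ug/mL, most plausibly between 60 ug/mL and 400 ug/mL, and quite possibly only as a limit.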

Compound 4, half-maximal cytotoxic concentration: 100 ug/mL
Beside the measured number, compound 4's estimate is 1.5-fold (0.18 log units) above it; measured number inside the range.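

In this assay, nitro in place of chloro ortho to a large group gives a 1.6-fold higher number from compound 3 to compound 4 (0.20 log units; within the scatter), so on this core the change makes no difference that can be told from the ordinary spread of repeated measurements. The same change was much larger on the core of compound 1, and the two steps clearly differ: the same change on two cores in this assay, an at least 14-fold higher number (1.14 log units; beyond the scatter) from compound 2 to compound 1 and a 1.6-fold higher number (0.20 log units; within the scatter) from compound 3 to compound 4, at least 8.8-fold (0.94 log units) apart, beyond the scatter of two such steps. This shows that the size of the step does not carry over from one core to the other in this series, but it does not show why, as the two pairs differ both in the core and in where the group sits on the ring, and the true size of the earlier step remains unknown, as it ends at a limit of the assay: the limit of > 100 ug/mL in this assay, at which 1 of the 4 values shown sits.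

The compounds shown leave open whether the core or the place of the group sets the size of the step, a question that would need both groups in both places on a single core. They also leave open how other groups in the same place, such as fluoro, methoxy or an amine, would read in this assay on either core.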